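Phenyl for Chloro on the Aryl Ketone Arm

A few compounds are considered here, and "the series" means these few. Any claim that something is new, unique, unknown or untested is made for them only; others in the source may bear on it.

Measured compounds:
compound 1 `CC(=O)c1ccc(Nc2ccnc(SCC(=O)c3ccc(Br)cc3)n2)cc1`, 21%
compound 2 `CC(=O)c1cccc(Nc2ccnc(SCC(=O)c3ccc(-c4ccccc4)cc3)n2)c1`, 14%
compound 3 `CC(=O)c1ccc(Nc2ccnc(SCC(=O)c3ccc(Cl)cc3)n2)cc1`, 27%

In a functional assay on MDA-MB-468 cells (Homo sapiens) for inhibition, read by sulforhodamine B assay, with a stated time of 48 h, tested at 10 uM (on this read-out lower numbers stand for less inhibition of growth and higher numbers for more inhibition of growth at the one concentration tested), compound 3 gives the highest of the three numbers. Its nearest neighbour is compound 1, and the step of a number 6 percentage points higher from compound 1 to compound 3 (within the scatter) falls within the scatter, so the two cannot be ranked. Compound 2 stands furthest away with 14%, a gap that lies beyond the scatter.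

Compound 4 `CC(=O)c1ccc(Nc2ccnc(SCC(=O)c3ccc(-c4ccccc4)cc3)n2)cc1` has not yet been measured. It arises from compound 3 by the change (phenyl in place of chloro on an aromatic carbon), the place being an aromatic carbon of a six-membered aromatic ring of carbon only, para to a large group.

For the measured compounds named here, no measured step covers exactly this exchange. Going by the values given here, the one measured step, chloro for bromo, is small and within the scatter, and it speaks only to halogen swaps. Among the compounds with values here, compound 2 is the only measured compound carrying the phenyl group, and it shows the lowest number, though it also differs from compound 4 elsewhere, so its value is a hint rather than a direct comparison.

The step of a number 10 percentage points lower from compound 3 to compound 4 (within the scatter) is therefore expected to be modest and downward. Compound 4 is estimated at 17%, with a range from 5% to 30%.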

Compound 4, percent growth inhibition at one concentration: 13%
Beside the measured number, compound 4's estimate is 4 percentage points above it; the range from low to high includes it.
By their numbers in this assay, from the lowest: compounds 4, 2, 1 and 3 (each within the scatter of the next, the first and the last beyond it).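

In this assay, the exchange of chloro for phenyl on an aromatic carbon para to a large group gives a number 14 percentage points lower from compound 3 to compound 4 (beyond the scatter) and so is the only step at this position, among those shown, that clears the scatter. The picture is less firm with the other halogen, as the exchange of bromo for phenyl gives a number 8 percentage points lower from compound 1 to compound 4 (within the scatter) and leaves those two compounds unranked, so the data separate phenyl from chloro but not from bromo. With phenyl held in place, 4-acetylphenyl in place of 3-acetylphenyl on the nitrogen gives a number 1 percentage points lower from compound 2 to compound 4 (within the scatter), so the two phenyl compounds cannot be ranked and neither acetylphenyl group stands apart from the other in this assay.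

No measurement is available that explains why phenyl at this position goes with a lower number than chloro. Also open, as far as these compounds go, is whether a methyl, a methoxy, an amine or a carboxylic acid on the same aromatic carbon would give a number nearer that of compound 3 or that of compound 4, and how any of these would read at concentrations other than the single one tested.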